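The source may hold more compounds than are shown below. What is called first, only, known or untested is meant among the compounds shown, and "the series" means these compounds.

Compound 1, `CCC(COC)Nc1nc(C)nc2c1nnn2-c1c(C)cc(C)cc1C`: 59.4 nM
Compound 2, `CCC(CC)Nc1nc(C)nc2c1nnn2-c1c(C)cc(C)cc1C`: 5.7 nM
Compound 3, `CCC(COC)Oc1nc(C)nc2c1nnn2-c1ccc(C(C)C)cc1Br`: 1.9 nM

These three compounds were measured in an in vitro assay on 293-EBNA cells for binding affinity to corticotropin-releasing factor receptor 1 (Homo sapiens); a higher number here means a weaker inhibitor, a lower number a stronger inhibitor. Compound 1 and compound 2 share a core and differ only by methyl in place of methoxy on a saturated chain carbon, two bonds along the chain from a nitrogen on an aromatic ring, a change that gave a 10-fold lower number from compound 1 to compound 2 (1.02 log units; beyond the scatter). Compound 3 gives the lowest number of the three; the difference between its core and that of compound 1 is not broken down here.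

Compound 4, `CCC(CC)Oc1nc(C)nc2c1nnn2-c1ccc(C(C)C)cc1Br`, has not yet been measured in this assay. It differs from compound 3 by methyl in place of methoxy on a saturated chain carbon, two bonds along the chain from an oxygen on an aromatic ring. Among the compounds with values here, this is the same kind of change as the one from compound 1 to compound 2, but not the same: there the place was two bonds along the chain from a nitrogen on an aromatic ring, here it is two bonds along the chain from an oxygen on an aromatic ring, and the cores differ as well. Because a 10-fold lower number from compound 1 to compound 2 (1.02 log units; beyond the scatter) was a large step, compound 4 is expected to show a lower number than compound 3, estimated as a 3.8-fold lower number from compound 3 to compound 4 (0.58 log units; beyond the scatter). The expected value for compound 4 is 0.5 nM, within a range of 0.15 nM to 1.6 nM.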

Compound 4, inhibition constant: 1.9 nM
Beside the measured number, compound 4's estimate is 3.8-fold (0.58 log units) below it; the whole stated range lies below it.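

In this assay, methyl in place of methoxy on a saturated chain carbon, two bonds along the chain from an oxygen on an aromatic ring, gave no change at the digits printed from compound 3 to compound 4 (within the scatter). The large step seen on the other core therefore did not carry over to this one, and the two steps differ by more than their scatter: the same change on two cores in this assay, a 10-fold lower number (1.02 log units; beyond the scatter) from compound 1 to compound 2 and no change at the digits printed (within the scatter) from compound 3 to compound 4, 10-fold (1.02 log units) apart, beyond the scatter of two such steps

Within the data shown here, this shows that the size of the change cannot be assumed to transfer between cores, but it rests on only one pair per core, and those pairs differ both in the atom bearing the chain and in the rest of the core, so it does not show which of these differences matters.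

The compounds shown leave open how the change would read with a nitrogen and an oxygen on otherwise identical cores. Also open, on these data alone, is how a hydroxyl, an amine or a longer chain would read at the same place in this assay.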